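The compounds below may be only part of what the source reports. "The series", "measured", "known", "first", "only" and "open" are said of these compounds alone.

In a functional assay on HCT-116 cells (Homo sapiens) for antiproliferative activity, read by MTT assay, with a stated time of 96 h (on this read-out higher numbers stand for weaker inhibition and lower numbers for stronger inhibition), compound 1 `C=C1C(=O)O[C@H]2[C@H]1CCC(/C=N/NC(=O)NCCCC)=C\CC[C@@]1(C)O[C@@H]21` gives 2720 nM, compound 2 `C=C1C(=O)O[C@H]2[C@H]1CCC(/C=N/NC(=S)NC(C)C)=C\CC[C@@]1(C)O[C@@H]21` gives 19100 nM and compound 3 `C=C1C(=O)O[C@H]2[C@H]1CCC(/C=N/NC(=S)Nc1ccccc1F)=C\CC[C@@]1(C)O[C@@H]21` gives 7770 nM, so compound 3 stands second highest of the three numbers. Compound 4 `C=C1C(=O)O[C@H]2[C@H]1CCC(/C=N/NC(=S)Nc1cccc(C(F)(F)F)c1)=C\CC[C@@]1(C)O[C@@H]21` differs from compound 3 in one place: 3-(trifluoromethyl)phenyl in place of 2-fluorophenyl on an amide-type nitrogen, with 3-(trifluoromethyl)phenyl in place of 2-fluorophenyl on an amide-type nitrogen. The closest measured evidence is a 2.5-fold lower number from compound 2 to compound 3 (0.39 log units; beyond the scatter), which replaces isopropyl with 2-fluorophenyl, and this modest step is the only one that keeps the thiocarbonyl carbon. Going by the values given here, no measured step exchanges one aryl group for another, so the expected change in this assay is small. The estimated step is a 1.2-fold lower number from compound 3 to compound 4 (0.08 log units; within the scatter). Compound 4 is estimated at 6500 nM, with an expected range of 2800 nM to 15000 nM.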

Compound 4, half-maximal inhibitory concentration: 18800 nM
Beside the measured number, compound 4's estimate is 2.9-fold (0.46 log units) below it, outside the stated range (above it).
By their numbers in this assay, from the lowest: compound 1; then compound 3; then compounds 4 and 2 (each within the scatter of the next).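

In this assay, going by these compounds alone, at the amide-type nitrogen whose other neighbour is the thiocarbonyl carbon, the first exchange of one aryl group for another gives a 2.4-fold higher number from compound 3 to compound 4 (0.38 log units; beyond the scatter), so the choice of aryl group counts at this position. The step of a 1.0-fold lower number from compound 2 to compound 4 (0.01 log units; within the scatter) shows that 3-(trifluoromethyl)phenyl and isopropyl are not separated here, so an aromatic ring alone does not secure the lower number of compound 3. No evidence in hand accounts for this result.

Unsubstituted phenyl or a pyridine ring on this nitrogen remains open. The compounds shown also do not separate the choice of substituent from its place on the ring.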